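The source may report more compounds than this note shows. Statements on the series, on what has been measured and on what is new or still open speak of the compounds shown alone.

Measured compounds:
- compound 1, `CC(=O)CCC(=O)NCCCN1CCN(CCCNc2ccnc3cc(Cl)ccc23)CC1`: 11000 nM in an ADME assay on L6 cells (Rattus norvegicus) for cytotoxicity; a lower number here means a stronger inhibitor, a higher number a weaker inhibitor
- compound 2, `O=C(CCCc1ccccc1)NCCCN1CCN(CCCNc2ccnc3cc(Cl)ccc23)CC1`: 11000 nM in this assay

Among the measured compounds shown here, compound 2 stands level with compound 1 on cytotoxicity, the only other compound measured in this assay: the step of no change at the digits printed from compound 1 to compound 2 (within the scatter) lies within the scatter, so exchanging the acetyl for a benzyl on the chain left the half-maximal inhibitory concentration where it was.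

Compound 3, `COc1cccc(C(=O)NCCCN2CCN(CCCNc3ccnc4cc(Cl)ccc34)CC2)c1`, is still to be measured in this assay. Its change from compound 2 is 3-methoxyphenyl in place of 3-phenylpropyl on a carbonyl carbon. For the measured compounds named here, no measured step touches exactly this change, but the one step that exists alters the same amide end of the molecule and was no change at the digits printed from compound 1 to compound 2 (within the scatter), that is, no change beyond the scatter. On that basis the step from compound 2 to compound 3 is expected to be no change at the digits printed from compound 2 to compound 3 (within the scatter), no shift beyond the scatter. Compound 3 is therefore estimated at 11000 nM in this assay, within a range from 5000 nM to 25000 nM.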

Compound 3, half-maximal inhibitory concentration: 9300 nM
For compound 3 the middle estimate is 1.2-fold (0.07 log units) above the measured one; the range from low to high includes it.
By their numbers in this assay, from the lowest: compounds 3, 1 and 2 (each within the scatter of the next).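

The earlier pair varied only a saturated chain on this carbonyl carbon. In this assay, a 3-methoxyphenyl, whose aromatic ring sits on the carbonyl carbon itself and which adds a hydrogen-bond acceptor, gives a 1.2-fold lower number from compound 2 to compound 3 (0.07 log units; within the scatter) and a 1.2-fold lower number from compound 1 to compound 3 (0.07 log units; within the scatter), so swapping either chain for this ring leaves the number within the scatter. No measurement at hand explains why these three different groups give values within the scatter of one another.

Still open, from the compounds shown here alone, is whether a carboxylic acid or an amine carried on the group at this carbonyl carbon would move the number beyond the scatter. It is also open whether the methoxy contributes anything, as the compounds shown include no unsubstituted phenyl on this carbonyl carbon to compare with compound 3.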